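Tert-butyl to 1-methylcyclopropyl at a limiting read-out

This account rests on a few compounds, and the source may have more. Where it says the series, first, only, none or still open, it means among the compounds named here.

In an ADME assay on HeLa cells (Homo sapiens) for cytotoxicity, read by ATP content, with a stated time of 3 days (a lower number here means that less compound is tolerated, a higher number that more compound is tolerated), compound 1 (`CC(C)(C)n1c(=O)n(Cc2cc3cc(Cl)ccc3n2CCCS(C)(=O)=O)c2cnccc21`) gives > 50000 nM as a limit of the assay, not a number. Compound 2 (`O=c1n(Cc2cc3ccc(Cl)cc3n2CCCCO)c2cnccc2n1C1CC1`) gives > 50000 nM in this assay and this too is a limit. Going by the values given here, both compounds therefore stand at the same place (the limit of > 50000 nM in this assay, at which 2 of the 2 values shown sit) and the series offers no measured step to work from. Compound 3 (`CC1(n2c(=O)n(Cc3cc4cc(Cl)ccc4n3CCCS(C)(=O)=O)c3cnccc32)CC1`) has 1-methylcyclopropyl in place of tert-butyl on an aromatic nitrogen with the rest of the structure of compound 1 unchanged. The expected step (a number no higher from compound 1 to compound 3 (the limit leaves the size open)) in this assay is none beyond the scatter, with no direction favoured. This expectation rests on compound 1 sitting at its limit (> 50000 nM) in the same assay. For compound 3 the estimate is 50000 nM with an expected range from 25000 nM to 100000 nM and a report as a limit is the likely outcome.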

Compound 3, half-maximal cytotoxic concentration: > 50000 nM
Compound 3: no number, only a limit; the forecaster's own chance of this, stated with the estimate: 85%; the middle value sits exactly at the limit.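

Compound 1 and compound 3 both read as limits, not numbers, in this assay, so no step can be read for 1-methylcyclopropyl in place of tert-butyl. The compounds shown leave open where the half-maximal cytotoxic concentration of each actually lies in this assay.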